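Working notes: methyl to chloro swap toward compound 3

The source may hold more compounds than are shown below. What is called first, only, known or untested is meant among the compounds shown, and "the series" means these compounds.

Measured so far in a functional assay on PC-3 cells (Homo sapiens) for cytotoxicity, read by sulforhodamine B assay, with a stated time of 48 h; a higher number here means a weaker inhibitor, a lower number a stronger inhibitor:
- compound 1, `C=CCOc1ccc(Br)cc1C(=O)c1cccnc1`, gives 59000 nM
- compound 2, `C=CCOc1ccc(C)cc1C(=O)c1cccnc1`, gives 98000 nM

Compound 2 holds the highest of the two numbers recorded in this assay; its nearest neighbour is compound 1, and the gap between them is within the scatter, so no order between the two can be claimed. For the measured compounds named here, the only step that bears on the present question is a 1.7-fold higher number from compound 1 to compound 2 (0.22 log units; within the scatter), bromo to methyl at the same aromatic carbon, and it did not move the number beyond the scatter.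

Compound 3, `C=CCOc1ccc(Cl)cc1C(=O)c1cccnc1`, is the untested member. The change is chloro in place of methyl on an aromatic carbon. Chloro enters where bromo sat in compound 1 and methyl in compound 2; the one recorded swap among these three groups was flat. On that basis no step beyond the scatter is expected in this assay, with a slight lean toward the number of compound 1. The expected step is a 1.5-fold lower number from compound 2 to compound 3 (0.18 log units; within the scatter). For compound 3 the estimate is 65000 nM, with a range of 30000 nM to 140000 nM.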

Compound 3, half-maximal inhibitory concentration: > 100000 nM
Compound 3 was reported as a limit; the forecaster's own chance of this, stated with the estimate: 10%; at least 1.5-fold (0.18 log units) between middle value and limit.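

Compound 3 is reported in this assay as a limit and not as a number: the limit of > 100000 nM in this assay, at which 1 of the 3 values shown sits. Against the methyl group, the change reads only as a floor, an at least 1.0-fold higher number from compound 2 to compound 3 (0.00 log units; that floor lies within the scatter), and against the bromo group it also reads only as a floor, an at least 1.6-fold higher number from compound 1 to compound 3 (0.22 log units; that floor lies within the scatter). Chloro at this carbon, para to an allyloxy group, therefore gives no sign of a lower number than either methyl or bromo, yet neither floor passes the scatter, so no order among the three groups can be claimed and the chloro change may be flat or larger than its floor.

Left open is how far the true value of compound 3 lies past its limit, and with it whether chloro differs at all from methyl or bromo in this assay. Also open, on these data alone, is whether a different kind of group on this carbon, such as an amine or a carboxylic acid, or a longer chain in place of the allyloxy group, would bring the number down beyond the scatter.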